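The source may hold more compounds than are shown below. What is called first, only, known or untested is meant among the compounds shown, and "the series" means these compounds.

Going by the values given here, in a functional assay on OCI-Ly3 cells (Homo sapiens) for inhibition, read by CellTiter-Glo, with stated times of 48 h and 96 h (on this read-out lower numbers stand for stronger inhibition of growth and higher numbers for weaker inhibition of growth), only two compounds have been measured so far. Compound 1 `CC(C)[C@@H](C(=O)N1CCC[C@H]1C(=O)N[C@@H](CCCNC(=N)N)C(=O)CF)N(C)C(=O)OCc1ccccc1` gives > 20000 nM, which is a limit of the assay and not a number. Among the compounds with values here, compound 2 `N=C(N)NCCC[C@H](NC(=O)[C@@H]1CCCN1C(=O)[C@@H](NC(=O)OCc1ccccc1)C1CCCCC1)C(=O)CF` gives 1450 nM, the only actual number available, so it has no measured neighbour to be ranked against. Compound 3 `N=C(N)NCCC[C@H](NC(=O)[C@@H]1CCCN1C(=O)[C@@H](NC(=O)OCc1ccccc1)c1ccccc1)C(=O)CF` departs from compound 2 in one place: phenyl in place of cyclohexyl on a saturated chain carbon bound to an amide-type nitrogen and a carbonyl carbon. There the phenyl stands in place of cyclohexyl. Within the data shown here, no measured step offers a direct guide. In this assay the expected 1.9-fold higher number from compound 2 to compound 3 (0.29 log units; within the scatter) is a modest weakening of growth inhibition, and this estimate is loose. For compound 3 the estimated value is 2800 nM, with an expected range of 900 nM to 10000 nM.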

Compound 3, concentration for 50% growth inhibition: 8050 nM
Estimate against measurement, compound 3: 2.9-fold (0.46 log units) below; the measured number falls inside the stated range.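

In this assay, going by these compounds alone, the first readable step at this position is a 5.6-fold higher number from compound 2 to compound 3 (0.74 log units; beyond the scatter), a weakening of growth inhibition on swapping cyclohexyl for phenyl. The two groups match in heavy atoms and in hydrogen-bond donors and acceptors, so this carbon distinguishes a saturated ring from an aromatic one even at equal counts. Compound 1 remains a limit and not a number, and gives no readable step: the limit of > 20000 nM in this assay, at which 1 of the 3 values shown sits.

Going by these compounds, what a cyclopentyl, a pyridyl or a tert-butyl group would give on this carbon remains open. So does whether this step holds on another core.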